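The compounds below may be only part of what the source reports. "The series", "measured", "known", "first", "only" and "open" are said of these compounds alone.

Measured so far:
compound 1 `CCCCCCCCC#Cc1cn(C/C=C\CN2C(=O)c3ccccc3C2=O)c(=O)[nH]c1=O`: in a functional assay on MIA PaCa-2 cells (Homo sapiens) for antiproliferative activity, read by MTT assay, with a stated time of 3 days (on this read-out lower numbers stand for stronger inhibition and higher numbers for weaker inhibition), compound 1 gives 68000 nM
compound 2 `CCCCC#Cc1cn(C/C=C\CN2C(=O)c3ccccc3C2=O)c(=O)[nH]c1=O`: in this assay compound 2 gives > 100000 nM, a limit and not a number

Compound 2 stands at the limit of > 100000 nM in this assay, at which 1 of the 2 values shown sits; the read-out for compound 2 is a limit only, so its true position is open. Going by the values given here, the single measured step, an at least 1.4-fold higher number from compound 1 to compound 2 (0.16 log units; that floor lies within the scatter), has a floor within the scatter, so no clear direction can be drawn from it.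

Compound 3 `CCCCc1ccc(C#Cc2cn(C/C=C\CN3C(=O)c4ccccc4C3=O)c(=O)[nH]c2=O)cc1` differs from compound 2 by 4-butylphenyl in place of butyl on a triple-bonded carbon. The step that bears on this change is an at least 1.4-fold higher number from compound 1 to compound 2 (0.16 log units; that floor lies within the scatter), where the larger group went with the lower number, though only at a size within the scatter, and no ring has yet been tried at this place. A number below the limit seen for compound 2 is expected, an at least 2.5-fold lower number from compound 2 to compound 3 (0.39 log units; beyond the scatter), with a reported limit still possible. Compound 3 is estimated at 40000 nM, ranging from 10000 nM to 150000 nM.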

Compound 3, half-maximal inhibitory concentration: 56000 nM
Compound 3: middle estimate off by 1.4-fold (0.15 log units), on the low side; the range from low to high includes it.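

The first ring shown on the triple-bonded carbon, 4-butylphenyl, does not separate from octyl in this assay: the step is a 1.2-fold lower number from compound 1 to compound 3 (0.08 log units; within the scatter). Against butyl the step is an at least 1.7-fold lower number from compound 2 to compound 3 (0.25 log units; that floor lies within the scatter), so no clear gain of the ring over butyl can be read from it. Compound 2 remains a limit and not a number: the limit of > 100000 nM in this assay, at which 1 of the 3 values shown sits.

On these data alone, whether the ring or the length of the substituent matters at this place stays open, as 4-butylphenyl and octyl differ in both. Also open, as far as these compounds go, is what an unsubstituted phenyl, or a phenyl carrying an amine or a carboxylic acid in place of butyl, would give on the shared core.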